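Removing a Chloro Group: Expected Effect on Cell Growth

The source may hold more compounds than are shown below. What is called first, only, known or untested is meant among the compounds shown, and "the series" means these compounds.

Measured compounds:
compound 1 `COc1ccc(-c2nc(C)c(C(=O)CSc3nc(N)c(C#N)c(-c4ccc(Cl)cc4)n3)s2)cc1` — 44%
compound 2 `COc1ccc(-c2nc(SCC(=O)c3sc(-c4ccccc4)nc3C)[nH]c(=O)c2C#N)cc1` — 90.4%

Of the compounds shown here, two have been tested in a functional assay on U-87MG ATCC cells for antiproliferative activity against U-87 MG (Homo sapiens), read by MTT assay, with a stated time of 48 h, tested at 10 uM; on this read-out higher numbers stand for a weaker effect at the one concentration tested and lower numbers for a stronger effect. In this assay compound 1 gives 44%, and compound 2 gives 90.4%. Compound 1 thus has the lower of the two numbers, meaning the stronger effect at the single concentration used, and compound 2 sits far above it, a gap well beyond the usual scatter of such measurements.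

Compound 3 `COc1ccc(-c2nc(C)c(C(=O)CSc3nc(N)c(C#N)c(-c4ccccc4)n3)s2)cc1` differs from compound 1 in a single place: hydrogen in place of chloro on an aromatic carbon. For the measured compounds named here, no measured pair shows what this particular change does, so the expectation for compound 3 rests on compound 1 alone. The step from compound 1 to compound 3 is expected to be small and toward a weaker effect, a number 12 percentage points higher from compound 1 to compound 3 (beyond the scatter). Compound 3 is estimated at 56%, with a likely range from 38% to 78%.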

Compound 3, a percentage reported as activity, at one concentration (the size of the read-out at that concentration, not a potency): 57.8%
For compound 3 the middle estimate is 1.8 percentage points below the measured one; measured number inside the range.
By their numbers in this assay, from the lowest: compound 1; then compound 3; then compound 2.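

Going from 4-chlorophenyl to phenyl in this assay gives a number 13.8 percentage points higher from compound 1 to compound 3 (beyond the scatter) on the shared core, the first direct reading of what this single change does. Taking away one chlorine atom from this aromatic carbon therefore weakens the effect at the one concentration tested, though only by a modest step. Nothing available explains why the number moves with this change.

From the compounds shown here alone, with only chloro and hydrogen compared at this carbon, it remains open whether chlorine itself matters or whether other groups could serve as well; a fluoro, a methoxy or an amine in the same place would help to answer this. The compounds shown also leave open whether the same change would give a similar step on a different core.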